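The source may hold more compounds than are shown below. What is called first, only, known or untested is meant among the compounds shown, and "the series" means these compounds.

Compound 2 `C[C@H](C(=O)Nc1nccs1)c1ccc(Cl)cc1` gives the highest of the two numbers in a functional assay on CHO cells for agonist activity at Free fatty acid receptor 2 (Homo sapiens), read by cAMP accumulation (a higher number here means a larger maximal response, a lower number a smaller maximal response), with 83%; compound 1 `CC(C)[C@H](C(=O)Nc1ncc(C(N)=O)s1)c1ccc(Cl)cc1` sits a clear distance lower at 59%, though the two differ in more than one place. Compound 3 `CCC[C@H](C(=O)Nc1nccs1)c1ccc(Cl)cc1` departs from compound 2 by ethyl in place of hydrogen on a saturated chain carbon, two bonds along the chain from an aromatic carbon and a carbonyl carbon. Among the compounds with values here, no measured pair isolates this change, so the expectation for this assay rests on the two values alone, which only hint that a larger group at that carbon may go with a smaller response. A modest step down, a number 11 percentage points lower from compound 2 to compound 3 (beyond the scatter), is expected, within or just beyond the scatter. Compound 3 is therefore estimated at 72%, in the range 52% to 90%.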

Compound 3, largest response reached (reported as efficacy), in percent of the reference or control that the assay uses: 108%
The estimate for compound 3 lay 36 percentage points below the measured number; the measured number lies above the stated range.
By their numbers in this assay, from the lowest: compound 1; then compound 2; then compound 3.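

Within the data shown here, this is the first pair to isolate a change at this saturated chain carbon, and in this assay ethyl in place of hydrogen gives a number 25 percentage points higher from compound 2 to compound 3 (beyond the scatter) in maximal response. For this one pair, then, the larger chain at this carbon goes with a larger response, not a smaller one. Nothing shown accounts for the rise. Going by these compounds, whether a longer chain such as butyl or a ring such as cyclopropyl at the same carbon would raise the response further or lower it stays open. So does the outcome with a carboxylic acid there.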